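Swapping a ring tail on a shared core

This account rests on a few compounds, and the source may have more. Where it says the series, first, only, none or still open, it means among the compounds named here.

Three compounds have been tested in a functional assay on SK-BR-3 cells (Homo sapiens) for inhibition, read by MTT assay, with a stated time of 2 days, tested at 100 uM; a higher number here means more inhibition of growth at the concentration tested, a lower number less inhibition of growth:
Compound 1 `CNC(=O)c1cc(Oc2ccc3nc(NC(=O)Nc4cc(C(F)(F)F)cc(C(F)(F)F)c4)sc3c2)ccn1` gives 96.3%.
Compound 2 `CNC(=O)c1cc(Oc2ccc3nc(NC(=O)c4ccc(Cl)cc4)sc3c2)ccn1` gives 83%.
Compound 3 `CNC(=O)c1cc(Oc2ccc3nc(NC(=O)Nc4ccc(N5CCN(C)CC5)cc4)sc3c2)ccn1` gives 86.4%.

All three share one core and differ only in the group at the far end. Compound 3 lies between compound 1 and compound 2, yet each gap is within the usual scatter, so none of the three can be set apart from the others. Compound 4 `CNC(=O)c1cc(Oc2ccc3nc(NC(=O)Nc4ccc(C5CCN(C(C)C)CC5)cc4)sc3c2)ccn1` keeps everything of compound 3 but carries 1-isopropylpiperidin-4-yl in place of 4-methylpiperazin-1-yl on an aromatic carbon, that is, 1-isopropylpiperidin-4-yl in place of 4-methylpiperazin-1-yl on an aromatic carbon. Among the measured compounds shown here, no measured pair shows what such a swap does. With the three measured numbers sitting close together, compound 4 is expected to stay in the same range, the expected step of a number 1.6 percentage points higher from compound 3 to compound 4 (within the scatter) being no larger than the scatter in either direction. For compound 4 the estimate in this assay is 88%, with a range from 72% to 99%.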

Compound 4, percent growth inhibition at one concentration: 91.6%
The estimate for compound 4 lay 3.6 percentage points below the measured number; low and high end bracket the measured number.
By their numbers in this assay, from the lowest: compounds 2, 3, 4 and 1 (each within the scatter of the next, the first and the last beyond it).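

Among the compounds shown here, this is the first pair that differs in one place only. In this assay, putting 1-isopropylpiperidin-4-yl in place of 4-methylpiperazin-1-yl gives a number 5.2 percentage points higher from compound 3 to compound 4 (within the scatter), so at this position on an aromatic carbon, para to a large group, the swap cannot be told apart from no effect at all. No available measurement offers an explanation for this result.

As far as these compounds go, it remains open whether a dimethylamino group or a carboxylic acid at the same place would stay in this range. A single concentration also leaves open whether compounds this close would still match at lower doses.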